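Quinoline thiosemicarbazones: benzyl amide substituent, antiproliferative estimate

The source may hold more compounds than are shown below. What is called first, only, known or untested is meant among the compounds shown, and "the series" means these compounds.

Measured compounds:
- compound 1, `FC(F)(F)c1ccccc1NC(=S)N/N=C/c1ccc2ccccc2n1`, 18800 nM
- compound 2, `CN(C)C(=S)N/N=C/c1ccc2cccnc2n1`, 970 nM
- compound 3, `Fc1ccccc1NC(=S)N/N=C/c1ccc2ccccc2n1`, > 100000 nM

Compound 1 gives 18800 nM in a functional assay on HeLa cells (Homo sapiens) for antiproliferative activity, read by sulforhodamine B assay, with a stated time of 72 h; on this read-out higher numbers stand for weaker inhibition and lower numbers for stronger inhibition. Compound 2, on a different core, gives 970 nM. For compound 3 the assay reports only a limit, > 100000 nM, so compound 3 stands at the weak end of the three without a number of its own; the limit is described by the limit of > 100000 nM in this assay, at which 1 of the 3 values shown sits.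

Among the measured compounds shown here, the only measured step is an at least 5.3-fold higher number from compound 1 to compound 3 (0.72 log units; beyond the scatter), which concerns the substituent on the phenyl ring, not the exchange of the ring-bearing group itself, so it does not bear directly on the change considered here.

Compound 4, `S=C(NCc1ccccc1)N/N=C/c1ccc2ccccc2n1`, differs from compound 3 by benzyl in place of 2-fluorophenyl on an amide-type nitrogen. For the measured compounds named here, no measured pair shows this exchange, so the size of the step is open; the value of compound 3 itself is only a limit, which leaves the starting point undefined.

Compound 4 is expected to give 30000 nM in this assay, with a wide range from 3000 nM to 100000 nM. The step of an at least 3.3-fold lower number from compound 3 to compound 4 (0.52 log units; beyond the scatter) that this estimate implies is therefore itself only an expectation, and a further limit rather than a number remains a real possibility.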

Compound 4, half-maximal inhibitory concentration: 62800 nM
Beside the measured number, compound 4's estimate is 2.1-fold (0.32 log units) below it; measured number inside the range.
By their numbers in this assay, from the lowest: compound 2; then compound 1; then compound 4. At a limit, above all of these: compound 3.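

In this assay compound 4 gives 62800 nM, so with benzyl on the amide-type nitrogen the shared core yields a measured number rather than a limit. Among the compounds shown here, the step, an at least 1.5-fold lower number from compound 3 to compound 4 (0.20 log units; that floor lies within the scatter), is the first reading of an exchange of the whole ring-bearing group on this nitrogen, and the exchange keeps the same count of heavy atoms and the six-membered aromatic ring of carbon only, while the fluorine leaves. The floor of this step lies within the scatter, so the true size of the exchange stays unknown because compound 3 sits at a limit: the limit of > 100000 nM in this assay, at which 1 of the 4 values shown sits.

Still open, on these data alone, is whether a trifluoromethyl group on the ring of the benzyl would shift the value of compound 4 in the way that group separates compound 1 from compound 3. Also open, as far as these compounds go, is how a longer chain such as phenethyl, or a saturated amine such as morpholine, would read on the amide-type nitrogen of this core, as compound 2 carries its dimethylamino group on a different core and offers no comparison.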